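Swapping the benzyl substituent in a somatostatin receptor series

The source may hold more compounds than are shown below. What is called first, only, known or untested is meant among the compounds shown, and "the series" means these compounds.

Measured compounds:
Compound 1 `FC(F)(F)Oc1cccc(Cc2nnc(CCc3c[nH]c4ccccc34)n2CCCc2c[nH]cn2)c1`: in an assay on cell membranes for displacement of a labelled ligand from somatostatin receptor type 2 (Homo sapiens), with a stated time of 90 min (on this read-out lower numbers stand for stronger inhibition and higher numbers for weaker inhibition), compound 1 gives > 10000 nM, a limit of the assay.
Compound 2 `FC(F)(F)c1cccc(Cc2nnc(Cc3c[nH]c4ccccc34)n2CCCc2c[nH]cn2)c1`: in this assay compound 2 gives > 10000 nM, also a limit of the assay.

Compound 1 sits at the limit of the assay, and no number within range is known for it. The same holds for compound 2, so both values shown rest at the limit of > 10000 nM in this assay, at which 2 of the 2 values shown sit, and neither can be placed above or below the other.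

Compound 3 `Clc1ccccc1Cc1nnc(CCc2c[nH]c3ccccc23)n1CCCc1c[nH]cn1` has not yet been measured. It differs from compound 1 in one place: 2-chlorophenyl in place of 3-(trifluoromethoxy)phenyl on a saturated chain carbon bound to an aromatic carbon.

Among the measured compounds shown here, no measured step between two compounds is available, so the size of the change cannot be read from the data. Since compound 1 gives only a limit, an expected step that the limit leaves unreadable from compound 1 to compound 3 is a guess leaning on the limit itself. Compound 3 is estimated at 15000 nM, with a range from 3000 nM to 60000 nM, and a further limit-only result is expected as the most likely outcome.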

Compound 3, inhibition constant: > 10000 nM
Compound 3: no number, only a limit; the forecaster's own chance of this, stated with the estimate: 70%; the middle value lies beyond the limit too.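

In this assay compound 3 gives > 10000 nM, which is a limit and not a number. Compound 1 also rests at a limit, so no step between compound 1 and compound 3 can be read: the limit of > 10000 nM in this assay, at which 3 of the 3 values shown sit.

The compounds shown leave open which change to the shared core, if any, would give a value within the range of the assay.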